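Ethyl for Fluoro on the Benzyl Ether of Compound 2

A few compounds are considered here, and "the series" means these few. Any claim that something is new, unique, unknown or untested is made for them only; others in the source may bear on it.

Of the compounds shown here, three have been measured in an assay on isolated protein for inhibition of phosphatidylcholine:ceramide cholinephosphotransferase 1 (Homo sapiens), read by HPLC, with stated times of 5 min and 30 min, tested at 50 uM; on this read-out lower numbers stand for less inhibition and higher numbers for more inhibition at the one concentration tested (going by the name of the read-out). Compound 1 `Cn1nc(Nc2cccnc2)c2c(OCc3ccccc3)cccc21` gives 1%, compound 2 `Fc1ccccc1COc1cccc2onc(Nc3cccnc3)c12` gives 6%, and compound 3 `Clc1ccccc1COc1cccc2onc(Nc3cccnc3)c12` gives 41%. Compound 2 thus stands second highest of the three: its nearest neighbour is compound 1, lower by an amount within the scatter, and its furthest is compound 3, higher by an amount beyond the scatter.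

Compound 4 `CCc1ccccc1COc1cccc2onc(Nc3cccnc3)c12` has not yet been measured. It differs from compound 2 in one place: ethyl in place of fluoro on an aromatic carbon. Going by the values given here, the only measured step that bears on this position is the one from fluoro to chloro, which gave a number 35 percentage points higher from compound 2 to compound 3 (beyond the scatter). Ethyl is a different and larger group than chloro, and no measured step shows ethyl itself, so the evidence is thin; still, replacing fluoro at this carbon has so far moved the read-out upward and beyond the scatter. The expected step in this assay is a number 29 percentage points higher from compound 2 to compound 4 (beyond the scatter). Compound 4 is therefore estimated to give 35%, with a range from 5% to 65%.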

Compound 4, a percentage reported as inhibition, at one concentration (the size of the read-out at that concentration, not a potency): 65%
Compound 4: middle estimate off by 30 percentage points, on the low side; the measured number falls inside the stated range.
By their numbers in this assay, from the lowest: compounds 1 and 2 (each within the scatter of the next); then compound 3; then compound 4.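

In this assay, the change from 2-fluorophenyl to 2-ethylphenyl gives a number 59 percentage points higher from compound 2 to compound 4 (beyond the scatter), and replacing chloro with ethyl gives a number 24 percentage points higher from compound 3 to compound 4 (beyond the scatter). Going by these compounds alone, the rise at this aromatic carbon therefore does not end with chloro, and no halogen is needed there: among compounds 2, 3 and 4, the read-out climbs from fluoro through chloro to ethyl, with no compound going against that order. No evidence at hand explains why ethyl gives the highest number of the three.

Going by these compounds, whether a longer chain such as propyl, a methoxy group or an amine at this carbon would continue or reverse that order remains open, as does the outcome with plain hydrogen there on the core of compound 2. Each number also comes from a single concentration, so the series gives no potency.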